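The source may hold more compounds than are shown below. What is called first, only, known or untested is meant among the compounds shown, and "the series" means these compounds.

Measured compounds:
compound 1 `COc1cc(C(=O)N2CCC(CCN3CCC(C(=O)c4nc5ccccc5n4CCOCc4ccco4)CC3)(c3ccccc3)C2)cc(OC)c1OC` — 7.93 nM
compound 2 `COc1ccc(C2(CCN3CCC(C(=O)c4nc5ccccc5[nH]4)CC3)CCN(C(=O)c3cc(OC)c(OC)c(OC)c3)C2)cc1OC` — 6.98 nM
compound 3 `CCOCCn1c(C(=O)C2CCN(CCC3(c4ccccc4)CCN(C(=O)c4cc(OC)c(OC)c(OC)c4)C3)CC2)nc2ccccc21` — 7.59 nM

In a functional assay for antagonist activity at Substance-P receptor (Cavia porcellus) (a higher number here means a weaker inhibitor, a lower number a stronger inhibitor), compound 3 stands second highest of the three numbers, and all three values lie within the scatter of one another. The step of a 1.0-fold lower number from compound 1 to compound 3 (0.02 log units; within the scatter) shows that exchanging the group on the aromatic nitrogen leaves the read-out essentially unchanged. Compound 4 `COc1cc(C(=O)N2CCC(CCN3CCC(C(=O)c4nc5ccccc5[nH]4)CC3)(c3ccccc3)C2)cc(OC)c1OC` differs from compound 3 by hydrogen in place of 2-ethoxyethyl on an aromatic nitrogen. Going by the values given here, the only step bearing on this place is the one from compound 1 to compound 3, and it was flat; compound 2, which also carries hydrogen on that aromatic nitrogen, gives a value within the scatter of compound 3, though its core differs elsewhere. No step beyond the scatter is therefore expected for a 1.0-fold lower number from compound 3 to compound 4 (0.01 log units; within the scatter). Compound 4 is estimated at 7.5 nM, range 3.5 nM to 16 nM.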

Compound 4, half-maximal inhibitory concentration: 7.44 nM
Compound 4: the middle estimate sits 1.0-fold (0.00 log units) above what was measured, and the stated range covers the measured number.
By their numbers in this assay, from the lowest: compounds 2, 4, 3 and 1 (each within the scatter of the next).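

In this assay, hydrogen in place of 2-ethoxyethyl on the aromatic nitrogen (a 1.0-fold lower number from compound 3 to compound 4 (0.01 log units; within the scatter)) and hydrogen in place of 2-((furan-2-yl)methoxy)ethyl (a 1.1-fold lower number from compound 1 to compound 4 (0.03 log units; within the scatter)) extend the flat reading to the unsubstituted nitrogen, where earlier only the two chains could be compared. Hydrogen and both chains therefore cannot be told apart at this position. Going by these compounds alone, a second place also reads flat for the first time: phenyl in place of 3,4-dimethoxyphenyl on a saturated ring carbon (a 1.1-fold higher number from compound 2 to compound 4 (0.03 log units; within the scatter)).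

Going by these compounds, whether an aminoethyl chain or a carboxylic acid on this aromatic nitrogen would stay equally flat remains open. Nothing available accounts for the flatness at either place.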